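Swapping tert-butyl for acetyl: what to expect

A few compounds are considered here, and "the series" means these few. Any claim that something is new, unique, unknown or untested is made for them only; others in the source may bear on it.

- Compound 1 (`Cc1cc(NC(=O)Nc2ccc(C(C)(C)C)cc2)c2ccccc2n1`): > 25000 nM (a limit)
- Compound 2 (`Cc1cc(NC(=O)Nc2ccc(C)c(Cl)c2)c2ccccc2n1`): > 25000 nM (a limit)
- Compound 3 (`CCc1ccc(NC(=O)Nc2cc(C)nc3ccccc23)cc1`): 16000 nM (a number)

The read-out here is an ADME assay on HEK293 cells (Homo sapiens) for cytotoxicity, with a stated time of 72 h; on this read-out lower numbers stand for an effect already at smaller amounts and higher numbers for an effect only at larger amounts of compound. Compound 1 stands only at a limit of the assay (> 25000 nM), not at a number. Compound 4 (`CC(=O)c1ccc(NC(=O)Nc2cc(C)nc3ccccc23)cc1`) carries acetyl in place of tert-butyl on an aromatic carbon, para to a large group (acetyl in place of tert-butyl on an aromatic carbon). For the measured compounds named here, one measured step bears on this place, ethyl in place of tert-butyl: an at least 1.5-fold lower number from compound 1 to compound 3 (0.19 log units; that floor lies within the scatter). A swap at this same place has thus shown no clear change, so none beyond the scatter is expected here. The expected step is small (an at least 1.2-fold lower number from compound 1 to compound 4 (0.09 log units; that floor lies within the scatter)). For compound 4 the estimate is 20000 nM, with an expected range from 9000 nM to 30000 nM.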

Compound 4, half-maximal effective concentration: > 25000 nM
Compound 4: only a limit was reported (the forecaster's own chance of this, stated with the estimate: 50%); middle value at least 1.2-fold (0.09 log units) away from the limit.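

Compound 4 reaches only a limit, as compound 1 does, so the step between these two cannot be read. Set against ethyl, acetyl gives an at least 1.5-fold higher number from compound 3 to compound 4 (0.19 log units; that floor lies within the scatter). This place has thus now taken a group with a hydrogen-bond acceptor without a clear change in this assay, but the readings here are capped: the limit of > 25000 nM in this assay, at which 3 of the 4 values shown sit.

On these data alone, whether an amine or a carboxylic acid at this place would produce a clear change stays open. So does how far beyond the limit compound 1 and compound 4 really lie.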